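Methyl substitution on the thiazole ring and oral potency

The source may report more compounds than this note shows. Statements on the series, on what has been measured and on what is new or still open speak of the compounds shown alone.

Measured so far in a functional assay on the whole organism for antagonist activity, with Rattus norvegicus as the target, at a dose of 10 mg/kg by the oral route; a higher number here means that more compound is needed for the effect, a lower number that less compound is needed:
compound 1 `CCc1c(OC)nc2nc(-c3nc(C)cs3)cn2c1C` — 10 mg/kg
compound 2 `CCc1c(OC)nc2nc(-c3nccs3)cn2c1C` — 10 mg/kg
compound 3 `CCc1c(SC)nc2nc(-c3nc(C)cs3)cn2c1C` — 50 mg/kg

Compound 2 stands level with compound 1 at the digits shown, and together these two carry the lowest numbers of the three in this assay; compound 3 is the furthest from compound 2, with a 5.0-fold higher number from compound 1 to compound 3 (0.70 log units; beyond the scatter) marking the gap that the methylsulfanyl-for-methoxy exchange brought. The step that bears most directly on the present question is no change at the digits printed from compound 1 to compound 2 (within the scatter), which shows that removing a methyl from the thiazole ring left the minimum effective dose where it was.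

Compound 4 `CCc1c(OC)nc2nc(-c3nc(C)c(C)s3)cn2c1C` has not yet been measured. It differs from compound 2 as follows: 4,5-dimethyl-1,3-thiazol-2-yl in place of 1,3-thiazol-2-yl on an aromatic carbon. Among the measured compounds shown here, this is a return of methyl to the thiazole ring, now with a second methyl on the same ring, and the only comparable precedent is the methyl-for-hydrogen step between compound 1 and compound 2, which was within the scatter. The methylsulfanyl step touches a different position and is not taken as a guide here.

On that basis the step of no change at the digits printed from compound 2 to compound 4 (within the scatter) is expected to stay within the scatter, with no clear direction. Compound 4 is therefore estimated at 10 mg/kg in this assay, with a range from 5 mg/kg to 30 mg/kg.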

Compound 4, minimum effective dose: > 50 mg/kg
Compound 4: only a limit was reported; the forecaster's own chance of this, stated with the estimate: 10%; middle value at least 5.0-fold (0.69 log units) from the limit.
By their numbers in this assay, from the lowest: compounds 1 and 2 (each within the scatter of the next); then compound 3.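

Until now the thiazole ring had seemed indifferent to methyl in this assay, with no change at the digits printed from compound 1 to compound 2 (within the scatter). A second methyl on that ring behaves differently, giving an at least 5.0-fold higher number from compound 1 to compound 4 (0.69 log units; beyond the scatter), and measured against the unsubstituted ring the 4,5-dimethyl-1,3-thiazol-2-yl group gives an at least 5.0-fold higher number from compound 2 to compound 4 (0.69 log units; beyond the scatter). The same kind of exchange, methyl in place of hydrogen on an aromatic carbon, therefore has no single outcome on this ring, and the size of both new steps remains bounded on one side only, as compound 4 carries a limit and not a number: the limit of > 50 mg/kg in this assay, at which 1 of the 4 values shown sits.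

The compounds shown leave open whether a single methyl on the other free carbon of the thiazole ring, without the methyl already present in compound 1, would have the same outcome, or whether it takes both methyl groups together. They also leave open how a longer chain such as ethyl, or an amine or a carboxylic acid, would read on the same ring, and whether the methylsulfanyl exchange, with a 5.0-fold higher number from compound 1 to compound 3 (0.70 log units; beyond the scatter), would combine with a change on the thiazole.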